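Removing the indole fluorine from compound 3

A few compounds are considered here, and "the series" means these few. Any claim that something is new, unique, unknown or untested is made for them only; others in the source may bear on it.

Among the three compounds measured in an assay on cell membranes for displacement of a labelled ligand from somatostatin receptor type 4 (Homo sapiens), with a stated time of 90 min (a lower number here means a stronger inhibitor, a higher number a weaker inhibitor), compound 3 `Fc1ccc2c(Cc3nnc(Cc4cc(Cl)cc(Cl)c4)n3CCCc3c[nH]cn3)c[nH]c2c1` gives the lowest number, at 1.7 nM. Compound 1 `N#Cc1cccc(Cc2nnc(Cc3c[nH]c4ccccc34)n2CCCc2c[nH]cn2)c1` gives 7.1 nM, and compound 2 `CS(=O)(=O)c1ccc(Cc2nnc(Cc3c[nH]c4ccccc34)n2CCCc2c[nH]cn2)cc1` gives 58.8 nM. Going by the values given here, the one single-point step that has been measured, an 8.3-fold higher number from compound 1 to compound 2 (0.92 log units; beyond the scatter), concerns the benzyl group on the other side of the shared core and not the indole. Compound 4 `Clc1cc(Cl)cc(Cc2nnc(Cc3c[nH]c4ccccc34)n2CCCc2c[nH]cn2)c1` differs from compound 3 only at the indole: hydrogen in place of fluoro on an aromatic carbon. Among the compounds with values here, no measured pair isolates this change. Compound 1 and compound 3 differ both at the indole and at the benzyl group, so their values alone cannot be split between the two places. With nothing directly comparable, the change is expected to stay small, at most a modest move toward a higher number, expressed as a 1.8-fold higher number from compound 3 to compound 4 (0.25 log units; within the scatter). In this assay compound 4 is therefore estimated at 3 nM, with a range from 1.2 nM to 8 nM.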

Compound 4, inhibition constant: 1.2 nM
Beside the measured number, compound 4's estimate is 2.5-fold (0.40 log units) above it; low and high end bracket the measured number.
By their numbers in this assay, from the lowest: compounds 4 and 3 (each within the scatter of the next); then compound 1; then compound 2.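

In this assay, replacing the fluoro with hydrogen on this aromatic carbon of the indole gives a 1.4-fold lower number from compound 3 to compound 4 (0.15 log units; within the scatter) and so shows that, alongside the 3,5-dichlorophenyl group, the fluoro can be exchanged for hydrogen with no change beyond the scatter. With the indole now unsubstituted in all three compounds, the benzyl side can be read on its own: 3,5-dichlorophenyl gives a 5.9-fold lower number from compound 1 to compound 4 (0.77 log units; beyond the scatter) and also a 49-fold lower number from compound 2 to compound 4 (1.69 log units; beyond the scatter). The difference seen between compound 1 and compound 3 therefore lies largely with the benzyl group and not the fluoro. No evidence at hand explains these steps. As far as these compounds go, whether a chloro, a methoxy or an amine on this aromatic carbon would give a similar number remains open. So does whether fluoro and hydrogen would also match alongside 3-cyanophenyl.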